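Allylamino to (2-methoxyethyl)amino on the shared core

The source may report more compounds than this note shows. Statements on the series, on what has been measured and on what is new or still open speak of the compounds shown alone.

Compound 2 `C=CCNc1cc(Oc2c(C)cc(/C=C/C#N)cc2C)nc(Nc2ccc(C#N)cc2)n1` gives 3050 nM in an ADME assay on MT4 cells (Homo sapiens) for cytotoxicity, read by MTT assay, with a stated time of 5 days; on this read-out lower numbers stand for higher toxicity in this test and higher numbers for lower toxicity in this test. Compound 1 `COC(Nc1cc(Oc2c(C)cc(/C=C/C#N)cc2C)nc(Nc2ccc(C#N)cc2)n1)OC` gives 3470 nM in this assay, and the step of a 1.1-fold lower number from compound 1 to compound 2 (0.06 log units; within the scatter) is within the scatter, so the two compounds stand close together. Compound 3 `COCCNc1cc(Oc2c(C)cc(/C=C/C#N)cc2C)nc(Nc2ccc(C#N)cc2)n1` differs from compound 2 by methoxymethyl in place of vinyl on a saturated chain carbon bound to a nitrogen on an aromatic ring. For the measured compounds named here, the one measured step, a 1.1-fold lower number from compound 1 to compound 2 (0.06 log units; within the scatter), also alters the group on a nitrogen on an aromatic ring and stays within the scatter, so in this assay no step beyond the scatter is expected here. The expected step is a 1.0-fold higher number from compound 2 to compound 3 (0.02 log units; within the scatter). Compound 3 is estimated at 3200 nM, range 1600 nM to 6400 nM.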

Compound 3, half-maximal cytotoxic concentration: 3190 nM
Compound 3: middle estimate off by 1.0-fold (0.00 log units), on the high side; the range from low to high includes it.
By their numbers in this assay, from the lowest: compounds 2, 3 and 1 (each within the scatter of the next).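

In this assay the step of a 1.0-fold higher number from compound 2 to compound 3 (0.02 log units; within the scatter) shows that the vinyl end of the chain can be replaced by methoxymethyl, which brings in an oxygen, without the number leaving the scatter. The step of a 1.1-fold lower number from compound 1 to compound 3 (0.04 log units; within the scatter) likewise separates 2-methoxyethyl from dimethoxymethyl by no more than the scatter, so allyl, 2-methoxyethyl and dimethoxymethyl on this nitrogen all read alike. No evidence bearing on this result is available.

Going by these compounds, whether a chain ending in an amine or a carboxylic acid would stay in this range remains open. So does the reading for a longer chain.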